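Notes on an amide series: a chain amine replaces a ring

The compounds below may be only part of what the source reports. "The series", "measured", "known", "first", "only" and "open" are said of these compounds alone.

The three measured compounds share an aryl amide and are read in an assay for activation of potassium voltage-gated channel subfamily KQT member 1 (Cavia porcellus); on this read-out lower numbers stand for stronger inhibition and higher numbers for weaker inhibition. Compound 1 `CCCCc1noc(-c2ccc(C(=O)NC[C@H]3CCCC3(C)C)cc2)n1` gives 2 nM. Compound 3 `CCCCc1noc(-c2ccc(C(=O)NCCC(C)(C)C)cc2)n1` gives 23 nM, and the step of a 12-fold higher number from compound 1 to compound 3 (1.06 log units; beyond the scatter) shows the cost of the ring-to-chain swap on the saturated chain carbon bound to the amide-type nitrogen. Compound 2 `CCCCCCOc1ccc(C(=O)NCC2CCCC(C)(C)C2)cc1` gives 370 nM, the highest number of the three, well beyond the scatter from both compound 3 and compound 1.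

Compound 4 `CCCCCCOc1ccc(C(=O)NCCN(CC)CC)cc1` is the unmeasured partner of compound 2, differing by (diethylamino)methyl in place of 3,3-dimethylcyclohexyl on a saturated chain carbon bound to an amide-type nitrogen. Within the data shown here, no measured pair carries a (diethylamino)methyl group, so the only step that bears on it is the one from compound 1 to compound 3, where a non-ring group replaced a ring group at the same place and the number rose clearly. The present swap also removes a ring and puts in a non-ring group, so a rise of similar or greater size is the working expectation.

Compound 4 is therefore expected to give about 3000 nM, within 700 nM to 15000 nM, an expected step of an 8.1-fold higher number from compound 2 to compound 4 (0.91 log units; beyond the scatter) from compound 2, with a real chance that only a limit is reported.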

Compound 4, half-maximal inhibitory concentration: 3500 nM
Beside the measured number, compound 4's estimate is 1.2-fold (0.07 log units) below it; the measured number falls inside the stated range.
By their numbers in this assay, from the lowest: compound 1; then compound 3; then compound 2; then compound 4.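

With (diethylamino)methyl in place of 3,3-dimethylcyclohexyl, a 9.5-fold higher number from compound 2 to compound 4 (0.98 log units; beyond the scatter) in this assay is a second clear loss of inhibition on swapping a ring for a non-ring group on a saturated chain carbon bound to an amide-type nitrogen. The earlier step of this kind, a 12-fold higher number from compound 1 to compound 3 (1.06 log units; beyond the scatter) on the core of compound 1, brought in a group of carbon only, whereas this one appears on a different core and brings in a group that holds nitrogen, so both listed swaps at this place raise the number and neither pair goes against that. Nothing available gives a reason for either rise.

The new step removes the ring and introduces the nitrogen together, so the compounds shown leave open which of the two changes goes with the rise. A piperidine ring at this place, which keeps a ring and holds the nitrogen within it, would set the two changes apart on the core of compound 2.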